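Methoxy for hydrogen at the aryl position: compound 4

The compounds below may be only part of what the source reports. "The series", "measured", "known", "first", "only" and "open" are said of these compounds alone.

Measured compounds:
compound 1 `COc1cc(/C=C/C(=O)c2cccc(-n3cc(-c4ccc(Cl)cc4)[nH]c3=O)c2)ccc1O`, a functional assay on SF-295 cells (Homo sapiens) for inhibition; a higher number here means a weaker inhibitor of growth, a lower number a stronger inhibitor of growth: 10500 nM
compound 2 `COc1cc(/C=C/C(=O)c2cccc(-n3cc(-c4ccccc4)[nH]c3=O)c2)cc(OC)c1OC`, this assay: 1900 nM
compound 3 `COc1cc(/C=C/C(=O)c2cccc(-n3cc(-c4ccccc4)[nH]c3=O)c2)ccc1O`, this assay: 3040 nM

Compound 2 holds the lowest of the three numbers in this assay; its gap to compound 3 is within the scatter, while its gap to compound 1 is beyond it. The unmeasured compound 4 `COc1ccc(-c2cn(-c3cccc(C(=O)/C=C/c4cc(OC)c(OC)c(OC)c4)c3)c(=O)[nH]2)cc1` differs from compound 2 by methoxy in place of hydrogen on an aromatic carbon, at the place described as on an aromatic carbon of a six-membered aromatic ring of carbon only, para to a large group.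

Among the measured compounds shown here, one measured step touches the same aromatic carbon: a 3.5-fold lower number from compound 1 to compound 3 (0.54 log units; beyond the scatter). That step exchanges chloro for hydrogen, not hydrogen for methoxy, so it only shows that this position is sensitive to substitution in the direction of a weaker inhibitor when a group is present. For the measured compounds named here, no step with methoxy at this carbon exists among the measured compounds. The expectation for compound 4 is therefore a step of a 1.6-fold higher number from compound 2 to compound 4 (0.20 log units; within the scatter), toward a somewhat higher number but not clearly beyond the scatter. Compound 4 is estimated at 3000 nM, within a range of 1200 nM to 8000 nM.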

Compound 4, concentration for 50% growth inhibition: 4950 nM
Compound 4: the middle estimate sits 1.7-fold (0.22 log units) below what was measured; the range from low to high includes it.
By their numbers in this assay, from the lowest: compounds 2, 3 and 4 (each within the scatter of the next, the first and the last beyond it); then compound 1.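

In this assay, among the compounds shown here, the change from phenyl to 4-methoxyphenyl gives a 2.6-fold higher number from compound 2 to compound 4 (0.42 log units; beyond the scatter), the first direct reading for a methoxy at this aromatic carbon. Chloro pointed the same way in a separate pair, a 3.5-fold lower number from compound 1 to compound 3 (0.54 log units; beyond the scatter), so in both pairs available the hydrogen-bearing compound holds the lower number, although each group is read only once and on a different remainder of the molecule. No available data explain this shared direction.

It remains open whether the methoxy step would repeat on the hydroxy-bearing partner, compound 3, where only the chloro and hydrogen forms are shown. Also open, from the compounds shown here alone, is how an amine, a carboxylic acid or a longer alkoxy chain at this carbon would compare with hydrogen.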